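Removing the 4-methoxybenzyl from the core of compound 1

A few compounds are considered here, and "the series" means these few. Any claim that something is new, unique, unknown or untested is made for them only; others in the source may bear on it.

Compound 1 `COc1ccc(Cn2nc(-c3ccccc3)c3cc(C(=N)Nc4cccc(C(F)(F)F)c4)nc(NC4CCCCC4)c32)cc1` stands only at a limit on the numbers available: in a functional assay on MDA-MB-231 cells (Homo sapiens) for cytotoxicity, read by MTT assay, with a stated time of 72 h (on this read-out higher numbers stand for weaker inhibition and lower numbers for stronger inhibition), compound 1 gives > 50000 nM, which is a limit of the assay and not a number. Compound 2 `COc1ccc(Cn2nc(-c3ccccc3)c3cc(C(=N)Nc4cccc(C(F)(F)F)c4)nc(Nc4cc(OC)c(OC)c(OC)c4)c32)cc1` carries 3,4,5-trimethoxyphenyl in place of cyclohexyl on a nitrogen on an aromatic ring; in this assay compound 2 gives > 50000 nM, again a limit. Compound 3 `COc1ccc(Cn2nc(-c3ccccc3)c3cc(C(=N)Nc4cccc(C(F)(F)F)c4)ncc32)cc1` has hydrogen in place of cyclohexylamino on an aromatic carbon; in this assay compound 3 gives > 50000 nM, also a limit. The steps a step that the two limits leave unreadable from compound 1 to compound 2 and a step that the two limits leave unreadable from compound 1 to compound 3 are therefore of no readable size, since the limit of > 50000 nM in this assay, at which 3 of the 3 values shown sit, shows every value sitting at the same limit.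

Compound 4 `N=C(Nc1cccc(C(F)(F)F)c1)c1cc2c(-c3ccccc3)n[nH]c2c(NC2CCCCC2)n1` differs from compound 1 in one place: hydrogen in place of 4-methoxybenzyl on an aromatic nitrogen. Going by the values given here, neither measured step touches this position, so nothing measured bears on it directly; the only guide is that every change made so far has left the series at the limit. No shift beyond the scatter is expected for a step that the limit leaves unreadable from compound 1 to compound 4, and the most likely outcome is a limit once more. Compound 4 is expected at 60000 nM, ranging from 20000 nM to 200000 nM.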

Compound 4, half-maximal inhibitory concentration: 24600 nM
Compound 4: the middle estimate sits 2.4-fold (0.39 log units) above what was measured; the measured number falls inside the stated range.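

In this assay, going by these compounds alone, compound 4 gives 24600 nM, the only value that is a number rather than a limit: the limit of > 50000 nM in this assay, at which 3 of the 4 values shown sit. The aromatic nitrogen of the five-membered ring is therefore the one place shown where a change takes a compound off the limit, whereas the steps to compound 2 and compound 3, made at the cyclohexylamino position, cannot be read. Swapping 4-methoxybenzyl for hydrogen gives an at least 2.0-fold lower number from compound 1 to compound 4 (0.30 log units; that floor lies within the scatter), which is only a floor on the size of the step, and that floor alone does not establish a shift beyond the scatter.

As far as these compounds go, it remains open whether a methyl, an ethyl or an unsubstituted benzyl on that nitrogen would stay at the limit or give a number like that of compound 4. Also open, from the compounds shown here alone, is how the cyclohexylamino position behaves once the ring nitrogen carries hydrogen, which a morpholine or a primary amine in that place would begin to show.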